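This account rests on a few compounds, and the source may have more. Where it says the series, first, only, none or still open, it means among the compounds named here.

In a functional assay on MCF7 cells (Homo sapiens) for antiproliferative activity, read by MTT assay (a lower number here means a stronger inhibitor, a higher number a weaker inhibitor), three compounds built on a shared core have been measured so far. Compound 1 (`CC1(C)CCc2c(ccc(C(=O)/C=C/c3ccc(OCc4cn(-c5ccc(Cl)cc5)nn4)cc3)c2O)O1`) is reported as "not active" (no number reported), and compound 3 (`CCc1ccccc1-n1cc(COc2ccc(/C=C/C(=O)c3ccc4c(c3O)CCC(C)(C)O4)cc2)nn1`) is also reported as "not active" (no number reported). Compound 3 therefore has no single number, and compound 1 is the one further entry without a number. Only compound 2 (`Cc1c(-n2cc(COc3ccc(/C=C/C(=O)c4ccc5c(c4O)CCC(C)(C)O5)cc3)nn2)cccc1[N+](=O)[O-]`) has a number, at 145000 nM. Compound 4 (`Cc1ccc(-n2cc(COc3ccc(/C=C/C(=O)c4ccc5c(c4O)CCC(C)(C)O5)cc3)nn2)cc1Br`) departs from compound 3 in one place, 3-bromo-4-methylphenyl in place of 2-ethylphenyl on an aromatic nitrogen. No measured step sizes this change. A modest step towards stronger inhibition is expected at most, reaching the neighbourhood of compound 2 at 145000 nM, and a result without a number remains quite possible. For compound 4 the estimated value is 100000 nM, with an expected range of 25000 nM to 250000 nM.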

Compound 4, half-maximal inhibitory concentration: "not active" (no number reported)
The entry for compound 4 holds no number; the estimate stays without a comparison.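

Compound 4, like compound 3, is reported as not active without a number in this assay, so no step can be read between them. No data shown here bear on this result. The compounds shown leave open how either compares with compound 2 at 145000 nM.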